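Hydroxy in place of ethyl on the amino acid side chain

The source may hold more compounds than are shown below. What is called first, only, known or untested is meant among the compounds shown, and "the series" means these compounds.

Measured so far:
compound 1, `CCC[C@@H](N)C(=O)NCc1ccccc1`: 35 mg/kg
compound 2, `CCCC[C@@H](N)C(=O)NCc1ccccc1`: > 71 mg/kg

In a functional assay on the whole organism (strain NMRI) for inhibition, with Mus musculus as the target, in the formalin test, with a stated time of 30 min (a lower number here means that less compound is needed, a higher number that more compound is needed for the effect), compound 1 gives 35 mg/kg. For compound 2 only the limit > 71 mg/kg is known, not a number, so compound 2 stands at the edge of what this assay can report (the limit of > 71 mg/kg in this assay, at which 1 of the 2 values shown sits). Among the measured compounds shown here, the one measured step, an at least 2.0-fold higher number from compound 1 to compound 2 (0.30 log units; that floor lies within the scatter), comes from adding a methyl further out on the chain.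

Compound 3, `N[C@H](CCO)C(=O)NCc1ccccc1`, differs from compound 2 by hydroxy in place of ethyl on a saturated chain carbon, three bonds along the chain from an amine nitrogen and a carbonyl carbon. For the measured compounds named here, this is a shortening of the chain paired with a new hydroxy, and no measured step here covers such a change, so the expected size for compound 3 in this assay rests on little. Because compound 2 sits at the limit (the limit of > 71 mg/kg in this assay, at which 1 of the 2 values shown sits), the step to compound 3 can only be estimated loosely; the estimate for compound 3 is an at least 1.4-fold lower number from compound 2 to compound 3 (0.15 log units; that floor lies within the scatter). Compound 3 is therefore expected to give about 50 mg/kg, with a range from 20 mg/kg to 140 mg/kg, and a real chance that only a limit is reported.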

Compound 3, dose for half-maximal effect: > 67 mg/kg
Compound 3 was reported as a limit; the forecaster's own chance of this, stated with the estimate: 50%; middle value at least 1.3-fold (0.12 log units) from the limit.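

In this assay compound 3 gives > 67 mg/kg, which is a limit and not a number. Measured against compound 1, the change of methyl to hydroxy on this side chain carbon gives an at least 1.9-fold higher number from compound 1 to compound 3 (0.28 log units; that floor lies within the scatter), so a real difference between these two compounds cannot be claimed from this floor, while the step between compound 2 and compound 3 cannot be read at all, as both are limits. What is new is that a side chain carrying a hydroxy ends at a limit just as the longer chain of compound 2 does, which leaves compound 1 as the only one of the three with a number in this assay.

The compounds shown leave open whether the true values of compound 2 and compound 3 lie just past their limits or far beyond them, and so whether the hydroxy helps, harms or changes nothing compared with the ethyl it replaces. An amine or a carboxylic acid in place of the hydroxy, or a plain methyl as a shorter side chain, would show whether any other group at this carbon gives a number in this assay.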